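A few compounds are considered here, and "the series" means these few. Any claim that something is new, unique, unknown or untested is made for them only; others in the source may bear on it.

Three compounds have numbers in a functional assay on L5178Y cells (Mus musculus); a lower number here means a less potent compound, a higher number a more potent compound, by a factor of ten per unit of this negative logarithm:

Compound 1 `CC1(C)N=C(N)N=C(N)N1c1cccc(Br)c1`: 5.9
Compound 2 `CC1(C)N=C(N)N=C(N)N1c1cccc(F)c1`: 5.24
Compound 3 `CCCCOc1cccc(N2C(N)=NC(N)=NC2(C)C)c1`: 5.95

Compound 3 stands highest of the three, though one step to it is within the scatter, a number 0.05 log units higher from compound 1 to compound 3 (within the scatter), and only the other is beyond it, a number 0.71 log units higher from compound 2 to compound 3 (beyond the scatter). Compound 4 `CC1(C)N=C(N)N=C(N)N1c1cccc(S(N)(=O)=O)c1` differs from compound 3 in one place: sulfamoyl in place of butoxy on an aromatic carbon. For the measured compounds named here, no measured step introduces a sulfamoyl, so the direct evidence is thin; the two steps that end at compound 3 replace a halogen with butoxy and either hold or rise. Removing the butoxy again is therefore expected to cost a little, and compound 4 is estimated at 5.4, between 4.7 and 6.1, an expected step of a number 0.55 log units lower from compound 3 to compound 4 (beyond the scatter).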

Compound 4, logarithm of the reciprocal of the active concentration, log(1/C): 3.13
The estimate for compound 4 lay 2.27 log units above the measured number; measured number outside the range, below it.
By their numbers in this assay, from the lowest: compound 4; then compound 2; then compounds 1 and 3 (each within the scatter of the next).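

In this assay bromo, fluoro and butoxy at this position gave numbers within a modest range, and sulfamoyl falls far outside it (a number 2.82 log units lower from compound 3 to compound 4 (beyond the scatter); a number 2.77 log units lower from compound 1 to compound 4 (beyond the scatter)). Even against the lowest of the earlier compounds the drop is large (a number 2.11 log units lower from compound 2 to compound 4 (beyond the scatter)), so the group on this aromatic carbon can matter far more than the first three compounds suggested. Nothing available explains the loss. From the compounds shown here alone, whether such a drop is peculiar to sulfamoyl stays open: a carboxylic acid or an amine at the same place would test that.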